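The compounds below may be only part of what the source reports. "The series", "measured", "known", "first", "only" and "open" are said of these compounds alone.

Measured so far:
- compound 1, `COc1cc(-c2cc(/C=C/C(=O)c3ccc(N)cc3)[nH]n2)cc(OC)c1OC`: 29%
- compound 2, `COc1ccc(-c2cc(/C=C/C(=O)c3ccc(OC)c(OC)c3)[nH]n2)cc1`: 23%

In a functional assay on Hs-578T cells (Homo sapiens) for cytotoxicity, read by sulforhodamine B assay, with a stated time of 48 h, tested at 10 uM (on this read-out higher numbers stand for a weaker effect at the one concentration tested and lower numbers for a stronger effect), compound 1 gives 29%, the highest of the two numbers at hand. The nearest is compound 2, which in this assay gives 23%, a number within the scatter of that of compound 1, so the two are not told apart by this read-out.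

The step under consideration runs from compound 1 to compound 3, `COc1cc(-c2cc(/C=C/C(=O)c3ccc(Cl)c(Cl)c3)[nH]n2)cc(OC)c1OC`, not yet measured in this assay. The change is 3,4-dichlorophenyl in place of 4-aminophenyl on a carbonyl carbon. For the measured compounds named here, no pair of measured compounds isolates a change of this kind, so nothing measured says how the 3,4-dichlorophenyl compares with the 4-aminophenyl on the carbonyl carbon; the only guide is that both measured compounds sit in a narrow band.

On that basis the step from compound 1 to compound 3 is expected to be small, in no set direction, and not clearly beyond the scatter: a number 1 percentage points higher from compound 1 to compound 3 (within the scatter). Compound 3 is therefore estimated at 30%, with a range from 12% to 52%.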

Compound 3, a percentage reported as activity, at one concentration (the size of the read-out at that concentration, not a potency): 63%
The estimate for compound 3 lay 33 percentage points below the measured number; the measured number lies above the stated range.
By their numbers in this assay, from the lowest: compounds 2 and 1 (each within the scatter of the next); then compound 3.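

In this assay the 3,4-dichlorophenyl in place of 4-aminophenyl on a carbonyl carbon gives a number 34 percentage points higher from compound 1 to compound 3 (beyond the scatter) and so a weaker effect at the one concentration tested. This position on the core of compound 1 can therefore move the read-out well beyond the narrow band of the two earlier numbers, which gave no sign of such a step. No measurement at hand accounts for the size or direction of this step.

The compounds shown leave open whether the step follows from losing the amine or from gaining the two chlorines, since both happen in one change. A plain phenyl, a 4-chlorophenyl or a 4-(dimethylamino)phenyl on the same carbonyl carbon would separate these two parts of the change.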